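Methoxy in place of methyl in compound 3

The compounds below may be only part of what the source reports. "The series", "measured", "known", "first", "only" and "open" are said of these compounds alone.

Among the compounds with values here, in a functional assay on K562 cells (Homo sapiens) for inhibition, read by trypan blue exclusion, with a stated time of 24 h, tested at 10 uM (a lower number here means less inhibition of growth, a higher number more inhibition of growth at the concentration tested), compound 3 (`Cc1ccc(NC(=O)COc2ccccc2C)c(C(N)=O)c1`) gives 45.6% as the lowest of the three numbers so far. Compound 1 (`Cc1ccccc1OCC(=O)Nc1ccc(Cl)cc1C(N)=O`) stands at 75.9% and compound 2 (`Cc1ccc(NC(=O)COc2ccccc2)c(C(N)=O)c1`) at 72% in the same read-out. Compound 4 (`COc1ccc(NC(=O)COc2ccccc2C)c(C(N)=O)c1`) carries methoxy in place of methyl on an aromatic carbon, meta to a carbamoyl group and para to a large group.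

Within the data shown here, two measured steps bear on this change. Methyl in place of chloro at that same carbon gave a number 30.3 percentage points lower from compound 1 to compound 3 (beyond the scatter) as a large step beyond the scatter, and this is the closest guide. Methyl in place of hydrogen on a different aromatic carbon gave a number 26.4 percentage points lower from compound 2 to compound 3 (beyond the scatter) as a modest step, so it bears only indirectly, showing that one small change can move the number past the scatter. Among the measured compounds shown here, no measured compound carries methoxy, and the carbon in question has been varied in one pair only. A partial move back towards the higher numbers is therefore the cautious expectation, with a wide range. The step expected in this assay is a number 9.4 percentage points higher from compound 3 to compound 4 (within the scatter) as a small rise that may not clear the scatter. Compound 4 is estimated at 55% with an expected range from 36% to 74% for now.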

Compound 4, percent growth inhibition at one concentration: 40.1%
Compound 4: middle estimate off by 14.9 percentage points, on the high side; measured number inside the range.
By their numbers in this assay, from the lowest: compounds 4 and 3 (each within the scatter of the next); then compounds 2 and 1 (each within the scatter of the next).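

In this assay, methoxy in place of methyl on the carbon para to a large group gives a number 5.5 percentage points lower from compound 3 to compound 4 (within the scatter), so the added oxygen and its hydrogen-bond acceptor bring no readable change at this carbon. Chloro now stands apart from two different groups here: alongside a number 30.3 percentage points lower from compound 1 to compound 3 (beyond the scatter), the new comparison gives a number 35.8 percentage points lower from compound 1 to compound 4 (beyond the scatter), and both replacements of chloro end at numbers within the scatter of each other. No measurement on hand accounts for this separation between chloro and the other two groups.

Still open, from the compounds shown here alone, is whether the higher number belongs to chloro alone or is shared by other groups on this carbon, such as fluoro, bromo, trifluoromethyl, nitrile or an amine. Also open, going by these compounds, is whether the effect of the methyl on the other aromatic carbon, seen so far only with methyl at this position, would carry over with chloro or methoxy here, and hydrogen at this carbon would give the missing reference point for all of these comparisons.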